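A Furyl Carbinol Replaces the Open Diol Chain

The source may hold more compounds than are shown below. What is called first, only, known or untested is meant among the compounds shown, and "the series" means these compounds.

Compound 2 `C=C1CC[C@H]2C(C)(C)CCC[C@]2(C)[C@H]1C/C=C(\CO)CCO` was tested in a functional assay on P388 cells (Mus musculus) for cytotoxicity (a lower number here means a stronger inhibitor, a higher number a weaker inhibitor), where compound 2 gives 6.3 ug/mL. It stands alongside compound 1 `C=C1CC[C@H]2C(C)(C)CCC[C@]2(C)[C@H]1C/C=C1/CCOC1=O`, which in this assay gives 6.7 ug/mL, and compound 3 `CC(=O)O[C@]1(C)CC[C@H]2C(C)(C)CCC[C@]2(C)[C@H]1C/C=C1/CCOC1=O`, which in this assay gives 7.8 ug/mL; the gaps among all three fall within the scatter, so none of them can be set apart from the others. Among the measured compounds shown here, the one recorded step among them, a 1.1-fold lower number from compound 1 to compound 2 (0.03 log units; within the scatter), swapped a ring-bearing group for an open chain at the same place and moved nothing beyond the scatter.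

Compound 4 `C=C1CC[C@H]2C(C)(C)CCC[C@]2(C)[C@H]1CC(O)c1ccoc1` is the next compound. Its change from compound 2 is (furan-3-yl)(hydroxy)methyl in place of 4-hydroxy-2-(hydroxymethyl)but-1-en-1-yl on a saturated chain carbon bound to a saturated ring carbon. For the measured compounds named here, this is again an exchange of one group for another at the same place, here with a ring entering rather than leaving; the only step that bears on it, a 1.1-fold lower number from compound 1 to compound 2 (0.03 log units; within the scatter), gave nothing beyond the scatter, and no other measured step touches this position. For compound 4 the expected step is therefore a 1.0-fold higher number from compound 2 to compound 4 (0.01 log units; within the scatter), nothing beyond the scatter. The estimate for compound 4 is 6.5 ug/mL, ranging from 3 ug/mL to 14 ug/mL.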

Compound 4, half-maximal inhibitory concentration: 3.6 ug/mL
Compound 4: the middle estimate sits 1.8-fold (0.26 log units) above what was measured, within the range that was stated.
By their numbers in this assay, from the lowest: compounds 4, 2, 1 and 3 (each within the scatter of the next, the first and the last beyond it).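

In this assay, the step to a five-membered aromatic ring with 1 hetero atom is a 1.8-fold lower number from compound 2 to compound 4 (0.24 log units; within the scatter) when it replaces the open 4-hydroxy-2-(hydroxymethyl)but-1-en-1-yl chain, and a 1.9-fold lower number from compound 1 to compound 4 (0.27 log units; within the scatter) when it replaces the group with the five-membered non-aromatic ring. The position on a saturated chain carbon bound to a saturated ring carbon has therefore now carried an aromatic ring, a non-aromatic ring and no ring at all, and none of these exchanges moved the number beyond the scatter. No supporting evidence bears on these results.

Going by these compounds, it remains open whether any group at this place can move the number beyond the scatter. A phenyl ring, an amine or a carboxylic acid there would put that to the test.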